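The compounds below may be only part of what the source reports. "The series", "measured", "known", "first", "only" and "open" are said of these compounds alone.

For the measured compounds named here, compound 2 `CN(C)CCCn1cnnc1-c1cc(Oc2ccc(NC(=O)Nc3ccc(F)c(Cl)c3)cc2F)ccn1` gives 890 nM in a functional assay on HT-29 cells (Homo sapiens) for antiproliferative activity, read by MTT assay, with a stated time of 72 h (on this read-out lower numbers stand for stronger inhibition and higher numbers for weaker inhibition), the lower of the two numbers measured so far; compound 1 `CN(C)CCn1cnnc1-c1cc(Oc2ccc(NC(=O)Nc3ccc(Cl)cc3Cl)cc2F)ccn1` gives 1890 nM, a gap beyond the usual scatter. Compound 3 `CN(C)CCCn1cnnc1-c1cc(Oc2ccc(NC(=O)Nc3ccc(Cl)cc3Cl)cc2F)ccn1` differs from compound 2 by 2,4-dichlorophenyl in place of 3-chloro-4-fluorophenyl on an amide-type nitrogen. Going by the values given here, no measured pair shows this change on its own, so its size is not known from these data. Compound 1, which carries the same 2,4-dichlorophenyl, gives 1890 nM. On that basis a small rise in the number, perhaps not beyond the scatter, is expected. The estimated step of a 1.5-fold higher number from compound 2 to compound 3 (0.16 log units; within the scatter) puts compound 3 at about 1300 nM, plausibly between 500 nM and 3500 nM.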

Compound 3, half-maximal inhibitory concentration: 680 nM
Compound 3: middle estimate off by 1.9-fold (0.28 log units), on the high side; measured number inside the range.
By their numbers in this assay, from the lowest: compounds 3 and 2 (each within the scatter of the next); then compound 1.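

In this assay, 2,4-dichlorophenyl in place of 3-chloro-4-fluorophenyl on an amide-type nitrogen gives a 1.3-fold lower number from compound 2 to compound 3 (0.12 log units; within the scatter), so this assay does not tell these two groups apart at this position. With 2,4-dichlorophenyl held constant, (dimethylamino)methyl in place of dimethylamino on the saturated chain gives a 2.8-fold lower number from compound 1 to compound 3 (0.44 log units; beyond the scatter), a modest step in which the chain change alone exceeds the scatter. Nothing measured here explains either step. As far as these compounds go, it remains open how an unsubstituted phenyl or a trifluoromethylphenyl would behave on that nitrogen. A still longer chain, or a morpholine in place of the dimethylamino group, also remains untested in the compounds shown.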